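The source may hold more compounds than are shown below. What is called first, only, known or untested is meant among the compounds shown, and "the series" means these compounds.

Measured in a functional assay on CHO-K1 cells for antagonist activity at transient receptor potential cation channel subfamily V member 1 (Homo sapiens), read by FLIPR; on this read-out lower numbers stand for stronger inhibition and higher numbers for weaker inhibition:
compound 1 `CC1CCC(Nc2nc(C(F)(F)F)ccc2CNC(=O)C(C)c2ccc(NS(C)(=O)=O)c(F)c2)CC1` gives 27.2 nM
compound 2 `CC(C(=O)NCc1ccc(C(F)(F)F)nc1Nc1ccc(F)cc1)c1ccc(NS(C)(=O)=O)c(F)c1` gives 39.2 nM
compound 3 `CC(C)OC1CCN(c2nc(C(F)(F)F)ccc2CNC(=O)C(C)c2ccc(NS(C)(=O)=O)c(F)c2)CC1` gives 3 nM

Compound 3 stands lowest of the three in this assay: the steps of a 9.1-fold lower number from compound 1 to compound 3 (0.96 log units; beyond the scatter) and a 13-fold lower number from compound 2 to compound 3 (1.12 log units; beyond the scatter) both lie beyond the scatter, while a 1.4-fold higher number from compound 1 to compound 2 (0.16 log units; within the scatter) lies within it. Compound 4 `CC(C(=O)NCc1ccc(C(F)(F)F)nc1N1CCCCCC1)c1ccc(NS(C)(=O)=O)c(F)c1` differs from compound 3 by azepan-1-yl in place of 4-isopropoxypiperidin-1-yl on an aromatic carbon. Among the compounds with values here, no measured pair isolates this change; the two steps that bear on it, a 9.1-fold lower number from compound 1 to compound 3 (0.96 log units; beyond the scatter) and a 13-fold lower number from compound 2 to compound 3 (1.12 log units; beyond the scatter), show that the 4-isopropoxypiperidin-1-yl group brought the number down markedly, so its replacement by a plain azepan-1-yl ring may give back part of that drop. Compound 4 is therefore expected at 12 nM, with a range of 4 nM to 40 nM. The step of a 4.0-fold higher number from compound 3 to compound 4 (0.60 log units; beyond the scatter) is expected to be moderate, towards a higher number, but staying under compounds 1 and 2.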

Compound 4, inhibition constant: 0.8 nM
The estimate for compound 4 lay 15-fold (1.18 log units) above the measured number; measured number below the stated range.
By their numbers in this assay, from the lowest: compound 4; then compound 3; then compounds 1 and 2 (each within the scatter of the next).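

In this assay, the position next to the ring nitrogen does not depend on the 4-isopropoxypiperidin-1-yl group for a low number: the smaller azepan-1-yl ring goes further, with a 3.8-fold lower number from compound 3 to compound 4 (0.57 log units; beyond the scatter). The gap to the amino-linked groups widens to a 49-fold lower number from compound 2 to compound 4 (1.69 log units; beyond the scatter) and a 34-fold lower number from compound 1 to compound 4 (1.53 log units; beyond the scatter), so both saturated rings, in compound 3 and compound 4, stand lower than the amino-linked compounds 1 and 2. No available evidence accounts for these differences.

As far as these compounds go, whether ring size or the isopropoxy group governs the step remains open, as both change together. A plain piperidin-1-yl group at this position would separate the two.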